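Nitro variants on a shared core: tolerance notes

The source may hold more compounds than are shown below. What is called first, only, known or untested is meant among the compounds shown, and "the series" means these compounds.

Compound 1 `O=c1[nH]c(SCc2cc([N+](=O)[O-])cc([N+](=O)[O-])c2)nc2ccccc12`, compound 2 `O=c1[nH]c(SCc2cccc([N+](=O)[O-])c2)nc2ccccc12` and compound 3 `O=c1[nH]c(SCc2ccc([N+](=O)[O-])cc2)nc2ccccc12` share one core and differ in the nitro pattern on the pendant ring. In an ADME assay on MRC5 cells (Homo sapiens) for cytotoxicity, read by neutral red uptake (a higher number here means that more compound is tolerated, a lower number that less compound is tolerated), compound 1 gives only a limit, > 64000 nM. In this assay compound 2 likewise gives a limit, > 64000 nM. In this assay compound 3 gives a limit as well, > 64000 nM. From compound 2 to compound 1 the change is nitro in place of hydrogen on an aromatic carbon, and the resulting step is a step that the two limits leave unreadable from compound 2 to compound 1. The difference between the cores of compound 2 and compound 3 is not broken down here. Compound 4 `O=c1[nH]c(SCc2ccc([N+](=O)[O-])cc2[N+](=O)[O-])nc2ccccc12`, not yet measured, differs from compound 3 by nitro in place of hydrogen on an aromatic carbon; this is the same kind of change as from compound 2 to compound 1, though here the entering group sits ortho to a large group rather than meta to a large group. Everything measured rests on (the limit of > 64000 nM in this assay, at which 3 of the 3 values shown sit). The step from compound 3 to compound 4 is expected to be a step that the limit leaves unreadable from compound 3 to compound 4 because all three measured compounds sit at the limit of > 64000 nM in this assay, at which 3 of the 3 values shown sit. Compound 4 is therefore estimated at 90000 nM, most likely again reported only as a limit.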

Compound 4, half-maximal cytotoxic concentration: > 64000 nM
Compound 4: a limit, no number (the forecaster's own chance of this, stated with the estimate: 80%); the middle value is on the limit's open side.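

Going by these compounds alone, compound 4, like compound 3, gives only a limit, and no step between the two can be read. The compounds shown leave open whether the nitro pattern on the pendant ring changes tolerance at all in this assay: the limit of > 64000 nM in this assay, at which 4 of the 4 values shown sit.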